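Ring substituents on the triazole nitrogen: compounds 1 to 4

The source may report more compounds than this note shows. Statements on the series, on what has been measured and on what is new or still open speak of the compounds shown alone.

Measured in a functional assay on RAW264.7 cells (Mus musculus) for inhibition, read by Griess assay, with stated times of 2 h and 24 h; a higher number here means a weaker inhibitor, a lower number a stronger inhibitor:
compound 1 `COc1ccc([C@@H]2CC(=O)c3c(O)cc(OCc4cn(Cc5ccccc5Cl)nn4)cc3O2)cc1O`: 6140 nM
compound 2 `COc1ccc([C@@H]2CC(=O)c3c(O)cc(OCc4cn(C5CCCC5)nn4)cc3O2)cc1O`: 10500 nM
compound 3 `COc1ccc([C@@H]2CC(=O)c3c(O)cc(OCc4cn(CC5CC5)nn4)cc3O2)cc1O`: 11900 nM

Compound 3 holds the highest of the three numbers in this assay, but a 1.1-fold higher number from compound 2 to compound 3 (0.05 log units; within the scatter) and a 1.9-fold higher number from compound 1 to compound 3 (0.29 log units; within the scatter) both lie within the scatter, so the three compounds are not separated. Compound 4 `COc1ccc([C@@H]2CC(=O)c3c(O)cc(OCc4cn(C5CCCCC5)nn4)cc3O2)cc1O` differs from compound 3 by cyclohexyl in place of cyclopropylmethyl on an aromatic nitrogen. For the measured compounds named here, the steps that bear on this are a 1.7-fold higher number from compound 1 to compound 2 (0.23 log units; within the scatter) and a 1.1-fold higher number from compound 2 to compound 3 (0.05 log units; within the scatter), each a change of the group on the aromatic nitrogen and each within the scatter. No step beyond the scatter is therefore expected for a 1.3-fold lower number from compound 3 to compound 4 (0.10 log units; within the scatter). Compound 4 is estimated at 9500 nM, with a range of 4500 nM to 20000 nM in this assay.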

Compound 4, half-maximal inhibitory concentration: 15600 nM
Beside the measured number, compound 4's estimate is 1.6-fold (0.22 log units) below it; the range from low to high includes it.
By their numbers in this assay, from the lowest: compounds 1, 2, 3 and 4 (each within the scatter of the next, the first and the last beyond it).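

Cyclohexyl on the aromatic nitrogen is not separated from cyclopropylmethyl or cyclopentyl, with a 1.3-fold higher number from compound 3 to compound 4 (0.12 log units; within the scatter) and a 1.5-fold higher number from compound 2 to compound 4 (0.17 log units; within the scatter) in this series. For the compounds shown here, the first step at this position to pass the scatter is modest, a 2.5-fold higher number from compound 1 to compound 4 (0.40 log units; beyond the scatter), although compound 2 and compound 3 each remain within the scatter of compound 1. No evidence to hand bears on this difference.

As far as these compounds go, what an amine or a carboxylic acid on this nitrogen would give remains open. So does whether the step from compound 1 belongs to the chlorine or to the benzyl group itself.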